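Three compounds measured, a fourth awaits its number

This account rests on a few compounds, and the source may have more. Where it says the series, first, only, none or still open, it means among the compounds named here.

Of the compounds shown here, three built on a shared core have been tested in a functional assay on KB cells (Homo sapiens) for antiproliferative activity, read by sulforhodamine B assay, with a stated time of 3 days; a higher number here means that more compound is needed for the effect, a lower number that less compound is needed. Compound 1, `CCC1=C(O)c2c(oc(-c3ccc(C)c(Cl)c3)cc2=O)C(CC)(CC)C1=O`, gives 39 uM in this assay. Compound 2, `CCC1=C(O)c2c(oc(-c3ccc(C)c(F)c3)cc2=O)C(CC)(CC)C1=O`, gives 28.1 uM. Compound 3, `CCC1=C(O)c2c(oc(-c3ccc(OC)c(F)c3)cc2=O)C(CC)(CC)C1=O`, gives 26.7 uM. The gaps among them are small: a 1.4-fold higher number from compound 2 to compound 1 (0.14 log units; within the scatter), a 1.5-fold lower number from compound 1 to compound 3 (0.16 log units; within the scatter), and a 1.1-fold lower number from compound 2 to compound 3 (0.02 log units; within the scatter). Among the measured compounds shown here, none of these steps leaves the scatter, so no compound can be called more or less active than another.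

Compound 2 and compound 1 differ in one place: chloro in place of fluoro on an aromatic carbon. Compound 2 and compound 3 differ in another place, and this is how the two cores differ: methoxy in place of methyl on an aromatic carbon.

Compound 4, `CCC1=C(O)c2c(oc(-c3ccc(OC)c(Cl)c3)cc2=O)C(CC)(CC)C1=O`, has not yet been measured in this assay. It differs from compound 3 in one place: chloro in place of fluoro on an aromatic carbon. For the measured compounds named here, this is the same kind of change as the one from compound 2 to compound 1, but the surroundings are not identical: in compound 1 the entering chloro sits ortho to a methyl group (1 heavy atom), whereas in compound 4 it sits ortho to a methoxy group (2 heavy atoms). Going by the values given here, the step from compound 2 to compound 1 in this assay is the only precedent available here.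

The expectation rests on compound 1 and compound 2, whose step a 1.4-fold higher number from compound 2 to compound 1 (0.14 log units; within the scatter) stayed within the scatter. Compound 4 is therefore expected to show a 1.3-fold higher number from compound 3 to compound 4 (0.12 log units; within the scatter) in this assay. The estimated value for compound 4 is 35 uM, with a likely range from 18 uM to 70 uM.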

Compound 4, concentration for half-maximal effect: 24.9 uM
Estimate against measurement, compound 4: 1.4-fold (0.15 log units) above; low and high end bracket the measured number.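

In this assay compound 4 stays within the scatter of all three earlier compounds, with a 1.1-fold lower number from compound 3 to compound 4 (0.03 log units; within the scatter), a 1.1-fold lower number from compound 2 to compound 4 (0.05 log units; within the scatter) and a 1.6-fold lower number from compound 1 to compound 4 (0.19 log units; within the scatter). Chloro in place of fluoro reads alike whether the ring carries a methyl or a methoxy group, in that neither step can be told from the scatter and the two steps cannot be told from each other: the same change on two cores in this assay, a 1.4-fold higher number (0.14 log units; within the scatter) from compound 2 to compound 1 and a 1.1-fold lower number (0.03 log units; within the scatter) from compound 3 to compound 4, 1.5-fold (0.17 log units) apart, within the scatter of two such steps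

Methoxy in place of methyl likewise reads alike with fluoro and with chloro on the ring, but this shows only that both changes stay silent on these cores, not that a change with a clear effect would carry over from one core to another in the same way: the same change on two cores in this assay, a 1.1-fold lower number (0.02 log units; within the scatter) from compound 2 to compound 3 and a 1.6-fold lower number (0.19 log units; within the scatter) from compound 1 to compound 4, 1.5-fold (0.17 log units) apart, within the scatter of two such steps

The four compounds vary only fluoro against chloro and methyl against methoxy on the one aromatic ring, so they leave open whether any change at these places can move the number beyond the scatter. From the compounds shown here alone, whether an amine, a carboxylic acid or a longer chain in the place of the methoxy group would do so stays open, as does the effect of any change on the shared core itself.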